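Urea in place of a bicyclic ketone on the azetidine core

This account rests on a few compounds, and the source may have more. Where it says the series, first, only, none or still open, it means among the compounds named here.

The series shares a core carrying a chlorophenyl-substituted heteroaromatic ring on an azetidine, whose nitrogen bears the varied acyl group. Compound 1 `O=C(N1CCCCCC1)N1CC(c2nc(-c3cccc(Cl)c3)no2)C1` carries a seven-membered cyclic urea and gives 47 nM in an assay on HEK293 cells for positive allosteric modulation of metabotropic glutamate receptor 5 (Homo sapiens), read by FLIPR; a lower number here means that less compound is needed, a higher number that more compound is needed for the effect. For the measured compounds named here, compound 2 `O=C([C@H]1CC2CCC1C2)N1CC(c2nc(-c3cccc(Cl)c3)no2)C1` carries a bicyclic carbocyclic ketone instead and gives 74 nM in this assay; it has the highest of the two numbers so far, yet the step of a 1.6-fold higher number from compound 1 to compound 2 (0.20 log units; within the scatter) lies within the scatter, so the two values cannot be told apart.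

Compound 3 `CC1CCN(C(=O)N2CC(c3nc(-c4cccc(Cl)c4)no3)C2)C1` differs from compound 2 in one place: a group of 6 heavy atoms (5 carbon, 1 nitrogen; one five-membered non-aromatic ring with 1 hetero atom) in place of a group of 7 heavy atoms (7 carbon; 2 five-membered non-aromatic rings of carbon only), on a carbonyl carbon. Going by the values given here, this change runs in the opposite sense to the only step measured so far, which replaced a nitrogen-containing ring with a carbocycle and moved the number a 1.6-fold higher number from compound 1 to compound 2 (0.20 log units; within the scatter). Since that swap changed little, the return to a nitrogen-containing ring of a smaller size is expected to change little as well, with at most a slight drift toward the number of compound 1.

Compound 3 is therefore expected to give 50 nM in this assay, between 20 nM and 130 nM, a step of a 1.5-fold lower number from compound 2 to compound 3 (0.17 log units; within the scatter).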

Compound 3, half-maximal effective concentration: > 10000 nM
Compound 3: only a limit was reported (the forecaster's own chance of this, stated with the estimate: 3%); middle value at least 200-fold (2.30 log units) away from the limit.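

Compound 3 reads as a limit in this assay, not as a number: the limit of > 10000 nM in this assay, at which 1 of the 3 values shown sits. The position on the carbonyl carbon had looked tolerant, since azepan-1-yl and the carbocyclic group of compound 2 gave values within the scatter of each other, but this change reveals a sharp edge, with an at least 130-fold higher number from compound 2 to compound 3 (2.13 log units; beyond the scatter) and an at least 210-fold higher number from compound 1 to compound 3 (2.32 log units; beyond the scatter). The second of these steps also shows that a nitrogen-containing ring on the carbonyl carbon does not by itself keep the effect, as compound 1 and compound 3 both carry one and still lie far apart, so the presence of that nitrogen does not sort these three compounds.

From the compounds shown here alone, what stays open is which feature of the 3-methylpyrrolidin-1-yl group goes with the loss, as the smaller ring and the methyl group enter together in compound 3. An unsubstituted pyrrolidin-1-yl or a piperidin-1-yl on the same carbonyl carbon would separate these two features and show whether the edge lies at the five-membered ring, at the methyl group, or only at their combination.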